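Acylurea series: indolyl in place of chloro-pyrazolylphenyl

A few compounds are considered here, and "the series" means these few. Any claim that something is new, unique, unknown or untested is made for them only; others in the source may bear on it.

Compound 1 `CN1CCN(CCCS(=O)(=O)c2ccc3nc(NC(=O)NC(=O)c4cccc(-n5cccn5)c4Cl)sc3c2)CC1` is the reference point of the set. In an assay on HEK293 cells for displacement of a labelled ligand from growth hormone secretagogue receptor type 1 (Homo sapiens), with a stated time of 60 min (a higher number here means a weaker inhibitor, a lower number a stronger inhibitor), compound 1 gives 8.8 nM, the lowest of the two numbers recorded. Its nearest measured neighbour is compound 3 `CS(=O)(=O)c1ccc2nc(NC(=O)NC(=O)c3ccccc3Cl)sc2c1`, which in this assay gives 120 nM, a gap beyond the usual scatter; the two differ in more than one place, so only the two values themselves can be set side by side. Compound 2 `CS(=O)(=O)c1ccc2nc(NC(=O)NC(=O)c3ccccc3Cl)oc2c1` sits at a limit of the assay, (the limit of > 10000 nM in this assay, at which 1 of the 3 values shown sits), and in this assay compound 2 gives > 10000 nM; this is a limit and not a number.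

The compound still to be measured, compound 4 `CN1CCN(CCCS(=O)(=O)c2ccc3nc(NC(=O)NC(=O)c4cc5c(ccn5C)cc4Cl)sc3c2)CC1`, keeps everything of compound 1 except the aryl group on the carbonyl carbon whose other neighbour is an amide-type nitrogen: 5-chloro-1-methyl-1H-indol-6-yl in place of 2-chloro-3-(1H-pyrazol-1-yl)phenyl on a carbonyl carbon. Going by the values given here, no measured pair shows this exchange, so its effect has not been observed directly. Both groups are fused or linked aromatics of similar overall size, and the rest of the molecule, including the sulfonyl side chain of compound 1, is unchanged.

The expected step is small, in either direction, and not clearly beyond the scatter. Compound 4 is estimated to give 15 nM in this assay, with a range from 4 nM to 60 nM. The expected change, a 1.7-fold higher number from compound 1 to compound 4 (0.23 log units; within the scatter), is modest.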

Compound 4, half-maximal inhibitory concentration: 0.57 nM
The estimate for compound 4 lay 26-fold (1.42 log units) above the measured number, and the stated range ends above it.
By their numbers in this assay, from the lowest: compound 4; then compound 1; then compound 3. At a limit, above all of these: compound 2.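

In this assay, going by these compounds alone, the aryl group on the carbonyl carbon whose other neighbour is an amide-type nitrogen now has a direct reading: 5-chloro-1-methyl-1H-indol-6-yl in place of 2-chloro-3-(1H-pyrazol-1-yl)phenyl gives a 15-fold lower number from compound 1 to compound 4 (1.19 log units; beyond the scatter) as the first step between compounds that differ in one place. With the sulfonyl side chain and the shared core unchanged, the step belongs to this exchange of aryl groups alone, and compound 4 at 0.57 nM shows that a 1H-pyrazol-1-yl group is not required at this place for a low number. Nothing measured on these compounds bears on why the exchange has so large an effect.

Still open is which part of the 5-chloro-1-methyl-1H-indol-6-yl group carries the step, as the compounds shown do not separate the 1-methyl group from the chlorine, and a hydrogen on the indole nitrogen or a fluorine in place of the chlorine would address this. Also open, on these data alone, is whether the same step holds with a different side chain on the sulfonyl group, such as a carboxylic acid or a shorter amine chain in place of the methylpiperazinylpropyl chain.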